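Ethoxycarbonyl to hydroxymethyl in a cell assay

The compounds below may be only part of what the source reports. "The series", "measured", "known", "first", "only" and "open" are said of these compounds alone.

- Compound 1 `COc1cc([C@H]2C[C@@]2(CO)C(=O)Nc2ccccc2Cl)cc(OC)c1OC`: > 100000 nM (a limit)
- Compound 2 `CCOC(=O)[C@@]1(C(=O)Nc2ccccc2Cl)C[C@H]1c1cc(OC)c(OC)c(OC)c1`: 30100 nM

Among the measured compounds shown here, in a functional assay on SW480 cells (Homo sapiens) for cytotoxicity, read by MTT assay, with a stated time of 48 h (a lower number here means a stronger inhibitor, a higher number a weaker inhibitor), compound 2 gives 30100 nM, the only exact number so far. Compound 3 `COc1cc([C@@H]2C[C@@]2(CO)C(=O)Nc2ccccc2Cl)cc(OC)c1OC` has hydroxymethyl in place of ethoxycarbonyl on a saturated ring carbon. Compound 1 also carries hydroxymethyl and reads > 100000 nM, which is a limit, so weaker inhibition is expected for compound 3. The expected change, a moderate one, is a 1.7-fold higher number from compound 2 to compound 3 (0.22 log units; within the scatter). The estimated value for compound 3 is 50000 nM, with an expected range from 15000 nM to 100000 nM.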

Compound 3, half-maximal inhibitory concentration: 10700 nM
Beside the measured number, compound 3's estimate is 4.7-fold (0.67 log units) above it, and the stated range ends above it.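

In this assay, hydroxymethyl in place of ethoxycarbonyl on this saturated ring carbon need not weaken the compound: the change gives a 2.8-fold lower number from compound 2 to compound 3 (0.45 log units; beyond the scatter) here. Compound 1 reads > 100000 nM as a limit. The same hydroxymethyl group therefore reads very differently in the two drawn configurations, with an at least 9.3-fold lower number from compound 1 to compound 3 (0.97 log units; beyond the scatter) in this assay, and this gap can be tied to one stereocentre: the fact that compounds 1 and 3 differ only in the configuration as drawn

As far as these compounds go, what stays open is how a carboxylic acid or an amine on this ring carbon would read, and whether ethoxycarbonyl responds to the same change in configuration.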